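The source may report more compounds than this note shows. Statements on the series, on what has been measured and on what is new or still open speak of the compounds shown alone.

Measured in a functional assay on LOX IMVI cells (Homo sapiens) for cytotoxicity, read by sulforhodamine B assay, with a stated time of 48 h; a higher number here means a weaker inhibitor of growth, a lower number a stronger inhibitor of growth:
- compound 1 `ClCc1ccccc1Cn1cnc2c(Cl)nc(Cl)nc21`: 150 nM
- compound 2 `ClCc1ccccc1Cn1cnc2c(Cl)ncnc21`: 2130 nM
- compound 3 `ClCc1ccc(Cn2cnc3ncnc(Cl)c32)cc1`: "not determined" (no result reported)

Compound 3 therefore has no number to stand on; it is described only through the compounds around it. Compound 4 `ClCc1ccc(Cn2cnc3nc(Cl)nc(Cl)c32)cc1` arises from compound 3 by one change, (chloro in place of hydrogen on an aromatic carbon), so that compound 4 carries the same pair of chloro groups as compound 1. For the measured compounds named here, the one measured step that matches this change runs the other way: a 14-fold higher number from compound 1 to compound 2 (1.15 log units; beyond the scatter), where removing a chloro group gave a much weaker inhibitor of growth. Adding the chloro group should thus pull the number down by a step of a similar size, though with no value for compound 3 the starting point is missing and the estimate must lean on compound 1, which in this assay gives 150 nM. For compound 4 a value close to that is expected, 200 nM, with a likely range from 50 nM to 900 nM.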

Compound 4, concentration for 50% growth inhibition: 1620 nM
Estimate against measurement, compound 4: 8.1-fold (0.91 log units) below, outside the stated range (above it).
By their numbers in this assay, from the lowest: compound 1; then compounds 4 and 2 (each within the scatter of the next).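

Compound 3 has no number in this assay, so the step from compound 3 to compound 4 cannot be read. The compounds shown leave open whether removing the chloro group from compound 4 would match the change seen in the other pair, a 14-fold higher number from compound 1 to compound 2 (1.15 log units; beyond the scatter). No further data shown here help to explain the value of compound 4.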